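Swapping one ring group on a shared core

The source may report more compounds than this note shows. Statements on the series, on what has been measured and on what is new or still open speak of the compounds shown alone.

Three compounds share one long core and differ only in a single ring-bearing group. In a functional assay on MCF7 cells (Homo sapiens) for antiproliferative activity (on this read-out lower numbers stand for stronger inhibition of growth and higher numbers for weaker inhibition of growth), compound 1 `CC/C=C\[C@H](C)[C@H](OC(N)=O)[C@@H](C)[C@H](O)[C@@H](C)C/C(C)=C\[C@H](C)[C@@H](O)[C@@H](C)/C=C\[C@@H](O)C[C@@H]1OC(=O)[C@H](C)C[C@H]1C` gives 5.8 nM and compound 2 `CC/C=C\[C@H](C)[C@H](OC(N)=O)[C@@H](C)[C@H](O)[C@@H](C)C/C(C)=C\[C@H](C)[C@@H](O)[C@@H](C)/C=C\[C@@H](O)C[C@H]1CCC(=O)O1` gives 6.4 nM while compound 3 `CC/C=C\[C@H](C)[C@H](OC(N)=O)[C@@H](C)[C@H](O)[C@@H](C)C/C(C)=C\[C@H](C)[C@@H](O)[C@@H](C)/C=C\[C@@H](O)C[C@@H]1OC(=O)NC[C@H]1C` gives 110 nM as its result. Compound 2 therefore sits at the strong end of this small set, with a 1.1-fold higher number from compound 1 to compound 2 (0.04 log units; within the scatter) on one side and a 17-fold higher number from compound 2 to compound 3 (1.24 log units; beyond the scatter) on the other.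

Compound 4 `CC/C=C\[C@H](C)[C@H](OC(N)=O)[C@@H](C)[C@H](O)[C@@H](C)C/C(C)=C\[C@H](C)[C@@H](O)[C@@H](C)/C=C\[C@@H](O)C[C@@H]1OC(=O)[C@H](C)[C@@H](OC)[C@H]1C` is not yet measured. It differs from compound 2 as follows: a group of 11 heavy atoms (8 carbon, 3 oxygen; one six-membered non-aromatic ring with 1 hetero atom) in place of a group of 6 heavy atoms (4 carbon, 2 oxygen; one five-membered non-aromatic ring with 1 hetero atom), on a saturated chain carbon, two bonds along the chain from a double-bonded chain carbon and an oxygen on a saturated carbon is the whole change. Its new group holds one six-membered non-aromatic ring with 1 hetero atom, the kind of ring compound 1 carries. The closest evidence is a 1.1-fold higher number from compound 1 to compound 2 (0.04 log units; within the scatter) as a swap without effect, and the large 19-fold higher number from compound 1 to compound 3 (1.28 log units; beyond the scatter) involves a ring of a different kind. Within the data shown here, no measured compound carries a group this large. The step expected in this assay is therefore small, a 1.9-fold higher number from compound 2 to compound 4 (0.27 log units; within the scatter) as a cautious guess. For compound 4 the estimated value is 12 nM with 4 nM as the expected lower end and 40 nM as the upper end.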

Compound 4, concentration for 50% growth inhibition: 3.8 nM
Compound 4: the middle estimate sits 3.2-fold (0.50 log units) above what was measured; the whole stated range lies above it.
By their numbers in this assay, from the lowest: compounds 4, 1 and 2 (each within the scatter of the next); then compound 3.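

In this assay, among these compounds, this position on the saturated chain carbon accepts a clearly larger group than the earlier compounds showed: the group of 11 heavy atoms gives a 1.7-fold lower number from compound 2 to compound 4 (0.23 log units; within the scatter) and methoxy in place of hydrogen on a saturated ring carbon gives a 1.5-fold lower number from compound 1 to compound 4 (0.18 log units; within the scatter), so neither step goes beyond the scatter. Among the compounds shown here, the same group gives a 29-fold lower number from compound 3 to compound 4 (1.46 log units; beyond the scatter), which leaves the ring with 2 hetero atoms of compound 3 as the only group here tied to a large step. Nothing measured here explains these results.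

The compounds shown leave open whether an amine, a carboxylic acid or a longer chain in place of methoxy on that ring carbon would also keep the number within the scatter. They also leave open whether the defined stereocentres of the new group matter.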